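Removing a fluorine from a naphthyl sugar and guessing the outcome

A few compounds are considered here, and "the series" means these few. Any claim that something is new, unique, unknown or untested is made for them only; others in the source may bear on it.

Three close relatives share a core built from a six-membered ring with one oxygen, carrying a naphthyloxy group. Compound 1 `O[C@@H]1[C@@H](O)[C@H](Oc2ccc3ccccc3c2)OC[C@H]1F` gives 32 uM in an ADME assay on CCD-1095SK cells (Homo sapiens) for antiproliferative activity, read by crystal violet staining, with a stated time of 96 h (a higher number here means that more compound is needed for the effect, a lower number that less compound is needed), compound 2 `O[C@@H]1[C@@H](F)[C@H](Oc2ccc3ccccc3c2)OC[C@H]1O` gives 12 uM, and compound 3 `O[C@H]1[C@H](Oc2ccc3ccccc3c2)OC[C@@H](O)[C@@H]1F` gives 72 uM, the highest of the three numbers, so compound 3 needs the most material for the effect. Compound 4 `O[C@@H]1CO[C@@H](Oc2ccc3ccccc3c2)[C@H](O)C1` keeps that core but the fluoro is gone: hydrogen in place of fluoro on a saturated ring carbon. Going by the values given here, no measured pair shows what taking the fluoro away does here, so the step can only be guessed. A small move in compound 4 toward a lower number is expected, a 1.4-fold lower number from compound 3 to compound 4 (0.16 log units; within the scatter). For compound 4 an estimated value of 50 uM, within 15 uM to 150 uM, is expected in this assay .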

Compound 4, concentration for half-maximal effect: 79 uM
For compound 4 the middle estimate is 1.6-fold (0.20 log units) below the measured one, and the stated range covers the measured number.
By their numbers in this assay, from the lowest: compound 2; then compound 1; then compounds 3 and 4 (each within the scatter of the next).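

Going by these compounds alone, replacing fluoro with hydrogen on this saturated ring carbon gives a 1.1-fold higher number from compound 3 to compound 4 (0.04 log units; within the scatter) in this assay and is the first direct reading of this change. At this position, the fluoro can be lost with no change in the number that exceeds the usual scatter. No supporting measurement explains this result.

Going by these compounds, it remains open whether an amine or a methoxy group on the same carbon would also leave the number unchanged, and whether losing the fluoro from compound 1 or compound 2 would behave alike.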